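This account rests on a few compounds, and the source may have more. Where it says the series, first, only, none or still open, it means among the compounds named here.

The series shares a styryl sulfone core, and compound 1 `COc1cc(OC)c(/C=C/S(=O)(=O)Cc2ccc(OC)c(OP(=O)(O)O)c2)c(OC)c1` is its reference point. In a functional assay on DU-145 cells (Homo sapiens) for antiproliferative activity, read by trypan blue exclusion (on this read-out higher numbers stand for weaker inhibition and lower numbers for stronger inhibition), compound 1 gives 2.5 nM, the lowest of the two numbers recorded. Its nearest neighbour is compound 2 `COc1ccc(CS(=O)(=O)/C=C/c2ccc(F)cc2OC)cc1`, which in this assay gives 10000 nM, a far higher number, well beyond the usual scatter. Compound 3 `COc1ccc(CS(=O)(=O)/C=C/c2cc(OC)c(OC)cc2OC)cc1` is recorded only as a limit of this assay, > 20000 nM, so no number is known for it; it sits at the limit of > 20000 nM in this assay, at which 1 of the 3 values shown sits.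

Compound 4 `COc1ccc(CS(=O)(=O)/C=C/c2c(OC)cc(OC)cc2OC)cc1` has not yet been measured. It differs from compound 1 by a hydrogen atom in place of a group of 5 heavy atoms (4 oxygen, 1 phosphorus; no ring), on an aromatic carbon. Compounds 2 and 3 also lack this group yet carry their methoxy groups in other arrangements, so they offer no direct guide to the step itself. Compound 4 is expected to keep a low number, with the step from compound 1 to compound 4 estimated as a 3.2-fold higher number from compound 1 to compound 4 (0.51 log units; beyond the scatter), a small move toward weaker inhibition, if any, close to the scatter. For compound 4 the estimate in this assay is 8 nM, with a range from 2 nM to 60 nM.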

Compound 4, half-maximal inhibitory concentration: 25 nM
Beside the measured number, compound 4's estimate is 3.1-fold (0.49 log units) below it; measured number inside the range.
By their numbers in this assay, from the lowest: compound 1; then compound 4; then compound 2. At a limit, above all of these: compound 3.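

For the compounds shown here, with this step the group of 5 heavy atoms (4 oxygen, 1 phosphorus) can be read on its own for the first time: the exchange for a hydrogen atom on this aromatic carbon, ortho to a methoxy group, gives a 10-fold higher number from compound 1 to compound 4 (1.00 log units; beyond the scatter) in this assay and is thus a modest change beyond the scatter. The group therefore counts toward the low number of compound 1, yet compound 4 at 25 nM shows that a low number does not depend on it entirely. No measurement shown here gives a cause for this step.

From the compounds shown here alone, whether a hydroxy group, a carboxylic acid or an amine on this carbon would give a number nearer to compound 1 or to compound 4 remains open. Also open, going by these compounds, is whether the same exchange would have a step of similar size with the methoxy groups arranged differently on the other aromatic ring.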